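Shifting One Chlorine on a Urea-Bearing Phenyl Ring

A few compounds are considered here, and "the series" means these few. Any claim that something is new, unique, unknown or untested is made for them only; others in the source may bear on it.

The measured compounds so far:
Compound 1, `O=C(Nc1ccccc1)Nc1cccc(CNc2nccnc2Cl)c1` — 16300 nM
Compound 2, `O=C(Nc1cccc(CNc2nccnc2Cl)c1)NC1CCCC1` — 23400 nM
Compound 3, `O=C(Nc1cccc(CNc2nccnc2Cl)c1)Nc1ccc(Cl)cc1Cl` — 6430 nM

These three share a core and differ only in the group on one nitrogen of the urea. In a functional assay on MGC-803 cells (Homo sapiens) for antiproliferative activity, read by MTT assay, with a stated time of 48 h (on this read-out lower numbers stand for stronger inhibition and higher numbers for weaker inhibition), compound 3 gives the lowest number of the three. The step of a 2.5-fold lower number from compound 1 to compound 3 (0.40 log units; beyond the scatter) is modest but beyond the scatter, as is a 3.6-fold lower number from compound 2 to compound 3 (0.56 log units; beyond the scatter); the step of a 1.4-fold higher number from compound 1 to compound 2 (0.16 log units; within the scatter) stays within the scatter.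

Compound 4, `O=C(Nc1cccc(CNc2nccnc2Cl)c1)Nc1ccc(Cl)c(Cl)c1`, keeps the same atoms as compound 3 but joins them differently: 3,4-dichlorophenyl in place of 2,4-dichlorophenyl on an amide-type nitrogen. Within the data shown here, no measured step moves a chlorine from one position of the ring to another, so the measured pairs bear on this change only indirectly: the two steps that introduce the 2,4-dichlorophenyl show that two chlorines on that ring lower the number modestly relative to phenyl or cyclopentyl, but they say nothing about where on the ring the chlorines should sit. The expectation for compound 4 in this assay is therefore a step of a 1.1-fold lower number from compound 3 to compound 4 (0.03 log units; within the scatter), that is, no change beyond the scatter, with a wide range on either side. The estimated value for compound 4 is 6000 nM, between 2500 nM and 14000 nM.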

Compound 4, half-maximal inhibitory concentration: 4970 nM
The estimate for compound 4 lay 1.2-fold (0.08 log units) above the measured number, and the stated range covers the measured number.
By their numbers in this assay, from the lowest: compounds 4 and 3 (each within the scatter of the next); then compounds 1 and 2 (each within the scatter of the next).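

In this assay, among these compounds, the change from 2,4-dichlorophenyl to 3,4-dichlorophenyl on the amide-type nitrogen gives a 1.3-fold lower number from compound 3 to compound 4 (0.11 log units; within the scatter) and so provides the first direct comparison of two chlorine arrangements, which cannot be told apart on this ring. The earlier compounds showed a lower number for only one dichlorophenyl group, but the second group shows one too, with a 3.3-fold lower number from compound 1 to compound 4 (0.52 log units; beyond the scatter) and a 4.7-fold lower number from compound 2 to compound 4 (0.67 log units; beyond the scatter), so among these compounds the gain over phenyl and cyclopentyl appears with both arrangements of the two chlorines. Nothing available explains these numbers or why the two arrangements read alike.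

Among the compounds shown here, with only two dichlorophenyl groups to compare, it remains open what a single chlorine on this ring would do, and whether a trifluoromethyl or methoxy group in place of the chlorines would keep the number as low. Going by these compounds, it is also open whether a carboxylic acid or an amine on the ring would leave the number there or push it back towards that of the unsubstituted phenyl.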